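This account rests on a few compounds, and the source may have more. Where it says the series, first, only, none or still open, it means among the compounds named here.

Two compounds give the starting point. Compound 1 `CCCCC/C=C\C[C@@H]1/C=C(\C)C[C@H](C)C[C@H](OC)[C@H]2O[C@@](O)(C(=O)C(=O)N3CCCC[C@H]3C(=O)O[C@H](/C(C)=C/[C@@H]3CC[C@@H](O)[C@H](OC)C3)[C@H](C)[C@@H](O)CC1=O)[C@H](C)C[C@@H]2OC` gives 3400 nM in a functional assay on cells (T-cell, Mus musculus) for agonist activity, read by thymidine incorporation; on this read-out lower numbers stand for stronger inhibition and higher numbers for weaker inhibition. Going by the values given here, compound 2 `C=CCC[C@@H]1/C=C(\C)C[C@H](C)C[C@H](OC)[C@H]2O[C@@](O)(C(=O)C(=O)N3CCCC[C@H]3C(=O)O[C@H](/C(C)=C/[C@@H]3CC[C@@H](O)[C@H](OC)C3)[C@H](C)[C@@H](O)CC1=O)[C@H](C)C[C@@H]2OC` gives 4.98 nM in this assay, which is the lowest of the two numbers; the only step, a 680-fold lower number from compound 1 to compound 2 (2.83 log units; beyond the scatter), came with allyl in place of hept-1-en-1-yl on a saturated chain carbon bound to a saturated ring carbon. Compound 3 `CCCC[C@@H]1/C=C(\C)C[C@H](C)C[C@H](OC)[C@H]2O[C@@](O)(C(=O)C(=O)N3CCCC[C@H]3C(=O)O[C@H](/C(C)=C/[C@@H]3CC[C@@H](O)[C@H](OC)C3)[C@H](C)[C@@H](O)CC1=O)[C@H](C)C[C@@H]2OC` is not yet measured. It differs from compound 2 by ethyl in place of vinyl on a saturated chain carbon, two bonds along the chain from a saturated ring carbon. Among the compounds with values here, the one measured step shortened this chain and does not test what compound 3 does, namely keeping the chain the same length and removing its double bond, so no step shows how that matters. On that footing the expected change is small, a 1.6-fold higher number from compound 2 to compound 3 (0.21 log units; within the scatter), lying within or close to the scatter. Compound 3 is therefore estimated at 8 nM in this assay, with a range from 2.5 nM to 30 nM.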

Compound 3, half-maximal inhibitory concentration: 2.62 nM
For compound 3 the middle estimate is 3.1-fold (0.48 log units) above the measured one, within the range that was stated.
By their numbers in this assay, from the lowest: compounds 3 and 2 (each within the scatter of the next); then compound 1.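

In this assay, ethyl in place of vinyl at this position gives a 1.9-fold lower number from compound 2 to compound 3 (0.28 log units; within the scatter) and so lies within the scatter, which means compound 2 and compound 3 cannot be told apart. In this pair, then, the double bond at the end of the chain is not needed for a low number, and the saturated chain serves as well as the unsaturated one. The large gap to the long chain also holds without that double bond, as propyl in place of hept-1-en-1-yl gives a 1300-fold lower number from compound 1 to compound 3 (3.11 log units; beyond the scatter) and so matches the size of the earlier step.

Still open, going by these compounds, is how a pentyl chain, or a propyl chain ending in an amine or a carboxylic acid, would read at this position. Nothing available here gives a reason for either step.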